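Dimethylamino for Methyl: Efficacy Expected to Hold

The source may hold more compounds than are shown below. What is called first, only, known or untested is meant among the compounds shown, and "the series" means these compounds.

Compound 2 `Cc1cc(-c2nc(C(c3ccc(F)cc3)c3ccc(F)cc3)sc2CC(=O)O)ccn1` gives 80% in an in vitro functional assay on HEK285-7 cells for antagonist activity at prostaglandin D2 receptor 2 (Homo sapiens), read by BRET and beta-arrestin recruitment (on this read-out higher numbers stand for larger maximal responses and lower numbers for smaller maximal responses), level with compound 1 `CS(=O)(=O)Nc1cccc(-c2nc(C(c3ccc(F)cc3)c3ccc(F)cc3)sc2CC(=O)O)c1`, which gives 80%; the step of no change at the digits printed from compound 1 to compound 2 (within the scatter) lies within the scatter. Compound 3 `CN(C)c1cc(-c2nc(C(c3ccc(F)cc3)c3ccc(F)cc3)sc2CC(=O)O)ccn1` differs from compound 2 by dimethylamino in place of methyl on an aromatic carbon, 2-methylpyridin-4-yl becoming 2-(dimethylamino)pyridin-4-yl. Because no change at the digits printed from compound 1 to compound 2 (within the scatter) exchanged a far larger group without moving the maximal response, compound 3 is expected to show no step beyond the scatter, no change at the digits printed from compound 2 to compound 3 (within the scatter). Compound 3 is therefore estimated at 80%, with a range from 65% to 95%.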

Compound 3, largest response reached (reported as efficacy), in percent of the reference or control that the assay uses: 80%
Compound 3: middle estimate and measured number agree at the digits printed; low and high end bracket the measured number.
By their numbers in this assay, from the lowest: compounds 1, 2 and 3 (each within the scatter of the next).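

At the position next to the ring nitrogen, dimethylamino, with its 3 heavy atoms and 1 hydrogen-bond acceptor, serves as well as methyl in this assay (no change at the digits printed from compound 2 to compound 3 (within the scatter)). The 2-(dimethylamino)pyridin-4-yl group also matches the 3-(methanesulfonamido)phenyl group (no change at the digits printed from compound 1 to compound 3 (within the scatter)), so this aromatic carbon has now tolerated an added nitrogen substituent without a step beyond the scatter. No evidence is available that bears on this result. From the compounds shown here alone, whether a primary amine, a morpholine or a longer chain at this position would hold the maximal response stays open. So does whether any group here can move it at all.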